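From pyridin-4-yl to 1-methyl-1H-pyrazol-4-yl on the shared core

The source may hold more compounds than are shown below. What is called first, only, known or untested is meant among the compounds shown, and "the series" means these compounds.

Measured so far in an ADME assay on BaF3 cells (Mus musculus) for antiproliferative activity, read by CCK-8 assay, with a stated time of 72 h; on this read-out higher numbers stand for weaker inhibition of growth and lower numbers for stronger inhibition of growth:
Compound 1 `O=C(CCSc1ccc2c(/C=C/c3ccccn3)n[nH]c2c1)NCc1cccc(C(F)(F)F)c1` gives 8030 nM
Compound 2 `CN1CCN(Cc2ccc(NC(=O)CCSc3ccc4c(/C=C/c5ccccn5)n[nH]c4c3)cc2C(F)(F)F)CC1` gives 2480 nM
Compound 3 `CN1CCN(Cc2ccc(NC(=O)CCSc3ccc4c(-c5ccncc5)n[nH]c4c3)cc2C(F)(F)F)CC1` gives 1060 nM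

Compound 3 holds the lowest number of the three, with compound 2 nearest and compound 1 furthest. Compound 4 (`CN1CCN(Cc2ccc(NC(=O)CCSc3ccc4c(-c5cnn(C)c5)n[nH]c4c3)cc2C(F)(F)F)CC1`) has not yet been measured in this assay and differs from compound 3 in a single group (1-methyl-1H-pyrazol-4-yl in place of pyridin-4-yl on an aromatic carbon), with 1-methyl-1H-pyrazol-4-yl in place of pyridin-4-yl on an aromatic carbon. For the measured compounds named here, one measured step bears on this change, since it exchanges a group on the same carbon (a 2.3-fold lower number from compound 2 to compound 3 (0.37 log units; beyond the scatter)), and that step was modest. Going by the values given here, no measured compound carries the entering group, so the direction rests on little. A step smaller than that one is therefore expected, most likely within the scatter and leaning slightly towards a lower number. The estimated change is a 1.4-fold lower number from compound 3 to compound 4 (0.15 log units; within the scatter) on this read-out. Compound 4 is expected at 750 nM within a range from 220 nM to 2500 nM once it is measured.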

Compound 4, concentration for 50% growth inhibition: 1400 nM
For compound 4 the middle estimate is 1.9-fold (0.27 log units) below the measured one; the measured number falls inside the stated range.
By their numbers in this assay, from the lowest: compounds 3, 4 and 2 (each within the scatter of the next, the first and the last beyond it); then compound 1.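

In this assay, the aromatic carbon takes 1-methyl-1H-pyrazol-4-yl as readily as pyridin-4-yl: a 1.3-fold higher number from compound 3 to compound 4 (0.12 log units; within the scatter), so exchanging a six-membered aromatic ring with 1 hetero atom for a five-membered one with 2 hetero atoms, at the same count of heavy atoms, gives no step beyond the scatter. The earlier gain over 2-(pyridin-2-yl)ethenyl, a 2.3-fold lower number from compound 2 to compound 3 (0.37 log units; beyond the scatter), is not clearly kept by the new group, since a 1.8-fold lower number from compound 2 to compound 4 (0.25 log units; within the scatter). Nothing measured here offers a reason for either step.

From the compounds shown here alone, it remains open whether a plain phenyl ring or a 1H-pyrazol-4-yl without the methyl would hold the number at this carbon, and whether an amine or a carboxylic acid on the ring would shift it beyond the scatter. Going by these compounds, whether the step carries over to the side chain of compound 1 also remains open.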